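The compounds below may be only part of what the source reports. "The series", "measured", "known", "first", "only" and "open" are said of these compounds alone.

Measured so far in a functional assay on HCT-116 cells (Homo sapiens) for antiproliferative activity, read by MTT assay, with a stated time of 72 h (a lower number here means a stronger inhibitor, a higher number a weaker inhibitor), are:
- compound 1 `NC1=NC2(CCSCC2)N(OCCCOc2ccc(Br)cc2)C(N)=N1` with 20 nM
- compound 2 `NC1=NC2(CCOCC2)N(OCCCOc2ccccc2Cl)C(N)=N1` with 70 nM
- compound 3 `NC1=NC2(CCSCC2)N(OCCCOc2cc(Cl)c(Cl)cc2Cl)C(N)=N1` with 1 nM

Compound 2 at 70 nM has the highest number of the three, which makes it the weakest inhibitor of this small set, and its gaps to both other compounds lie beyond the scatter.

Compound 4 `NC1=NC2(CCOCC2)N(OCCCOc2cc(Cl)c(Cl)cc2Cl)C(N)=N1` keeps the core of compound 2 and changes one group on an oxygen on a saturated carbon, with 2,4,5-trichlorophenyl in place of 2-chlorophenyl (2,4,5-trichlorophenyl in place of 2-chlorophenyl on an oxygen on a saturated carbon).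

Within the data shown here, one measured step bears on this change. The same 2,4,5-trichlorophenyl group replaced 4-bromophenyl in a 20-fold lower number from compound 1 to compound 3 (1.30 log units; beyond the scatter) and gave a large drop, well beyond the scatter. That step started from a different group on a different core, so it need not carry over in full. Among the measured compounds shown here, no measured pair shows what the core change does alone.

A large move towards a lower number in this assay is still expected, and the expected size is a 14-fold lower number from compound 2 to compound 4 (1.15 log units; beyond the scatter) in this estimate.

The estimate for compound 4 is 5 nM with 1.5 nM to 20 nM as the expected range.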

Compound 4, half-maximal inhibitory concentration: 2750 nM
Compound 4: middle estimate off by 550-fold (2.74 log units), on the low side; the whole stated range lies below it.
By their numbers in this assay, from the lowest: compound 3; then compound 1; then compound 2; then compound 4.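

In this assay, the 2,4,5-trichlorophenyl group on an oxygen on a saturated carbon does not lower the number wherever it is placed: it gave a 20-fold lower number from compound 1 to compound 3 (1.30 log units; beyond the scatter) on one core, yet it gave a 39-fold higher number from compound 2 to compound 4 (1.59 log units; beyond the scatter) on the other. Both steps are large and they point in opposite directions, so the earlier step alone was no safe guide to this change, and what this group does here depends on its setting, either on the group it replaces or on the core that carries it. Nothing measured on these compounds explains the reversal.

Compound 3 at 1 nM and compound 4 at 2750 nM carry the same 2,4,5-trichlorophenyl group on different cores, but the 2-chlorophenyl and 4-bromophenyl groups each appear on one core only, so the shown compounds cannot separate the part played by the core from the part played by the group that leaves. Also open, on these data alone, is how the number would respond on either core if an amine or a carboxylic acid stood on the phenyl ring, or if a longer chain carried it.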